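Anilinomethyl Amide Replaces Hydroxyphenoxymethyl in the Series

The source may hold more compounds than are shown below. What is called first, only, known or untested is meant among the compounds shown, and "the series" means these compounds.

The series shares the core of compound 1 `CC(C)C[C@H](N)c1cc(C(F)(F)F)ccc1N1CCN(C(=O)[C@H](C)Cc2ccc(Cl)cc2)CC1`, which in an assay on HEK293 cells for displacement of a labelled ligand from Melanocortin receptor 4 (Homo sapiens) (a lower number here means a stronger inhibitor, a higher number a weaker inhibitor), gives 31 nM. Compound 2 `CC(C)C[C@H](N)c1cc(C(F)(F)F)ccc1N1CCN(C(=O)C(C)Cc2ccc(Cl)cc2O)CC1` gives 36 nM in this assay, and the step of a 1.2-fold higher number from compound 1 to compound 2 (0.06 log units; within the scatter) lies within the scatter. Compound 3 `CC(C)C[C@H](N)c1cc(C(F)(F)F)ccc1N1CCN(C(=O)COc2ccc(O)cc2)CC1` gives 4600 nM in this assay, the highest of the three numbers; the steps of a 150-fold higher number from compound 1 to compound 3 (2.17 log units; beyond the scatter) and a 130-fold higher number from compound 2 to compound 3 (2.11 log units; beyond the scatter) are both large.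

Compound 4 `CC(C)C[C@H](N)c1cc(C(F)(F)F)ccc1N1CCN(C(=O)CNc2ccccc2)CC1` differs from compound 3 by anilino in place of 4-hydroxyphenoxy on a saturated chain carbon bound to a carbonyl carbon. The change keeps the carbonyl and the saturated chain carbon bound to it and replaces only what stands beyond. The two measured steps that reach compound 3 alter that same part of the molecule, and both moved the number by a large amount; neither, however, introduces anilino, so they set the scale of what such a replacement can do rather than its direction. Compound 1 and compound 2 carry 1-(4-chlorobenzyl)ethyl or 1-(4-chloro-2-hydroxybenzyl)ethyl, while the anilinomethyl of compound 4 resembles the (4-hydroxyphenoxy)methyl of compound 3 more closely than either. The step of a 1.8-fold lower number from compound 3 to compound 4 (0.26 log units; within the scatter) is therefore expected to be modest, if anything toward a lower number, with wide uncertainty. Compound 4 is estimated at 2500 nM in this assay, between 600 nM and 10000 nM.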

Compound 4, inhibition constant: 3600 nM
Compound 4: the middle estimate sits 1.4-fold (0.16 log units) below what was measured; low and high end bracket the measured number.
By their numbers in this assay, from the lowest: compounds 1 and 2 (each within the scatter of the next); then compounds 4 and 3 (each within the scatter of the next).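

In this assay, anilino in place of 4-hydroxyphenoxy on a saturated chain carbon bound to a carbonyl carbon gives a 1.3-fold lower number from compound 3 to compound 4 (0.11 log units; within the scatter) and so leaves the number within the scatter, even though this one exchange removes both oxygens of the leaving group and brings in a nitrogen. The large gap to the two chlorinated groups now recurs with a second group at this position, since anilinomethyl in place of 1-(4-chlorobenzyl)ethyl gives a 120-fold higher number from compound 1 to compound 4 (2.06 log units; beyond the scatter) and anilinomethyl in place of 1-(4-chloro-2-hydroxybenzyl)ethyl gives a 100-fold higher number from compound 2 to compound 4 (2.00 log units; beyond the scatter) on the same carbonyl carbon. No supporting evidence bears on this result, so these notes offer no explanation for it.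

The large steps to anilinomethyl change the chain and the ring substituents together, so the share of each remains unresolved. As far as these compounds go, a 4-chloroanilino group on the same saturated chain carbon, or a longer chain carrying anilino, would separate these contributions, and whether either recovers any of the gap remains open.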